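Replacing a Saturated Ring by an Aromatic Ether: Expected Cytotoxicity

The compounds below may be only part of what the source reports. "The series", "measured", "known", "first", "only" and "open" are said of these compounds alone.

Of the compounds shown here, three have been measured in an ADME assay on HepG2 cells (Homo sapiens) for cytotoxicity, read by luminescence, CellTiter-Glo and ATP content, with a stated time of 72 h; a higher number here means that more compound is needed for the effect, a lower number that less compound is needed. Compound 1 `COc1cccc(CNCCCNc2ccnc3cc(C4CCCCC4)ccc23)c1O` gives 1080 nM, compound 2 `COc1ccc(F)cc1CNCCCNc1ccnc2cc(C3CCCCC3)ccc12` gives 2290 nM, and compound 3 `COc1cccc(CNCCCNc2ccnc3cc(-c4ccc(F)cc4)ccc23)c1O` gives 6840 nM. Compound 2 stands second highest of the three numbers, nearest to compound 1 and furthest from compound 3. Compound 4 `COc1cccc(Oc2ccc3c(NCCCNCc4cc(F)ccc4OC)ccnc3c2)c1` has not yet been measured; relative to compound 2 it carries 3-methoxyphenoxy in place of cyclohexyl on an aromatic carbon. The step in which cyclohexyl gave way to 4-fluorophenyl on an aromatic carbon, a 6.3-fold higher number from compound 1 to compound 3 (0.80 log units; beyond the scatter), bears most directly on this change. The other measured step, a 2.1-fold higher number from compound 1 to compound 2 (0.33 log units; beyond the scatter), concerns a different part of the molecule. A rise of comparable size is therefore expected, a 3.9-fold higher number from compound 2 to compound 4 (0.59 log units; beyond the scatter). Compound 4 is expected at 9000 nM, within a range from 3000 nM to 30000 nM.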

Compound 4, half-maximal effective concentration: 7100 nM
The estimate for compound 4 lay 1.3-fold (0.10 log units) above the measured number; the measured number falls inside the stated range.
By their numbers in this assay, from the lowest: compound 1; then compound 2; then compounds 3 and 4 (each within the scatter of the next).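

In this assay, putting 3-methoxyphenoxy in place of cyclohexyl on this aromatic carbon gives a 3.1-fold higher number from compound 2 to compound 4 (0.49 log units; beyond the scatter). The rise seen earlier on losing cyclohexyl therefore also appears with a different entering group, one that brings an ether oxygen and a methoxy group, and with 5-fluoro-2-methoxyphenyl at the other end of the molecule. No measurement here accounts for this rise. The compounds shown do not separate the contributions of the ether oxygen and the methoxy group. Also open, from the compounds shown here alone, is what a plain phenoxy, an amine or a carboxylic acid would give on this carbon.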